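This account rests on a few compounds, and the source may have more. Where it says the series, first, only, none or still open, it means among the compounds named here.

Measured so far:
compound 1 `Cc1c(CO/N=C/c2c(-c3ccccc3)nn(-c3ccccc3)c2Oc2ccc(Cl)cc2)cccc1-c1ccccc1` — -15%
compound 2 `CCOC(=O)c1ccc(CO/N=C/c2c(C)nn(C)c2Oc2ccc(Cl)cc2)cc1` — 20.9%

In a functional assay on MKN-45 cells (Homo sapiens) for antiproliferative activity, tested at 1 uM (on this read-out lower numbers stand for less inhibition and higher numbers for more inhibition at the one concentration tested (going by the name of the read-out)), compound 2 gives 20.9%, the higher of the two numbers; compound 1 gives -15%, a gap beyond the scatter. Compound 3 `Cc1nn(C)c(Oc2ccc(Cl)cc2)c1/C=N/OCc1ccc(C(F)(F)F)cc1` differs from compound 2 in one place: trifluoromethyl in place of ethoxycarbonyl on an aromatic carbon. Among the compounds with values here, no two measured compounds differ in a single place, so there is no precedent for the size of such a step. With the trifluoromethyl entering where the ethoxycarbonyl leaves, the expected step from compound 2 to compound 3 in this assay is a number 5.9 percentage points lower from compound 2 to compound 3 (within the scatter), not beyond the scatter. Compound 3 is estimated at 15%, range -10% to 40%.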

Compound 3, a percentage reported as inhibition, at one concentration (the size of the read-out at that concentration, not a potency): 27.6%
Beside the measured number, compound 3's estimate is 12.6 percentage points below it; the range from low to high includes it.
By their numbers in this assay, from the lowest: compound 1; then compounds 2 and 3 (each within the scatter of the next).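

In this assay, within the data shown here, the first single-place step reads a number 6.7 percentage points higher from compound 2 to compound 3 (within the scatter), so on an aromatic carbon para to a large group, the two groups cannot be told apart. Trifluoromethyl has no hydrogen-bond acceptors and ethoxycarbonyl has two, yet this pair shows no separation beyond the scatter. Nothing available explains this step. Still open, from the compounds shown here alone, is whether a carboxylic acid or an amine at this position would give a number beyond the scatter of compound 2 and compound 3.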